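The compounds below may be only part of what the source reports. "The series", "measured", "known", "first", "only" and "open" are said of these compounds alone.

The compounds share one core, and compound 1 (`Cc1ncc([N+](=O)[O-])n1CCSC(=S)N1CCC(OC(=O)C(Cl)Cl)CC1`) carries a (dichloromethyl)carbonyl group on an oxygen on a saturated carbon. In an ADME assay on HeLa cells (Homo sapiens) for cytotoxicity (a higher number here means a weaker inhibitor, a lower number a stronger inhibitor), compound 1 gives > 1000 ug/mL, which is a limit of the assay and not a number. Compound 3 (`Cc1ncc([N+](=O)[O-])n1CCSC(=S)N1CCC(OC(=O)CSC(=S)N2CCCC2)CC1`) gives > 1000 ug/mL, also a limit. Compound 2 (`Cc1ncc([N+](=O)[O-])n1CCSC(=S)N1CCC(OC(=O)CSC(=S)N2CCCCC2)CC1`) gives a measured 980 ug/mL. Compound 1 therefore stands at the limit of > 1000 ug/mL in this assay, at which 2 of the 3 values shown sit.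

Compound 4 (`Cc1ncc([N+](=O)[O-])n1CCSC(=S)N1CCC(OS(C)(=O)=O)CC1`) has methylsulfonyl in place of (dichloromethyl)carbonyl on that oxygen: methylsulfonyl in place of (dichloromethyl)carbonyl on an oxygen on a saturated carbon. Among the measured compounds shown here, no measured step makes this exchange, so the closest evidence comes from changes to the group on the carbonyl carbon. These gave an at least 1.0-fold lower number from compound 1 to compound 2 (0.00 log units; that floor lies within the scatter) and a step that the two limits leave unreadable from compound 1 to compound 3. Putting pyrrolidin-1-yl in place of piperidin-1-yl on a thiocarbonyl carbon gave an at least 1.0-fold higher number from compound 2 to compound 3 (0.00 log units; that floor lies within the scatter). No readable step among these goes beyond the scatter, so no step beyond the scatter is expected in this assay. The expected change is a number no higher from compound 1 to compound 4 (the limit leaves the size open). Compound 4 is estimated at 1000 ug/mL, with an expected range from 450 ug/mL to 2000 ug/mL.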

Compound 4, half-maximal inhibitory concentration: > 1000 ug/mL
Compound 4 was reported as a limit; the forecaster's own chance of this, stated with the estimate: 60%; the middle value lies on the limit itself.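

In this assay, among the compounds shown here, compound 4 gives > 1000 ug/mL, which is a limit of the assay and not a number; compound 1 also stands at a limit, so no step between compound 1 and compound 4 can be read. The compounds shown leave open whether methylsulfonyl in place of (dichloromethyl)carbonyl on that oxygen changes the number at all.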